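A Fluorine at the Far End of the Phenyl Ring

The source may report more compounds than this note shows. Statements on the series, on what has been measured and on what is new or still open speak of the compounds shown alone.

Compound 1, `CN(C)CCn1cnnc1-c1cc(Oc2ccc(NC(=O)N/N=C/c3c[nH]c4ccccc34)cc2F)ccn1`, gives 790 nM in a functional assay on MKN-45 cells (Homo sapiens) for cytotoxicity, read by MTT assay, with a stated time of 72 h; on this read-out lower numbers stand for stronger inhibition and higher numbers for weaker inhibition.
Compound 2, `CN(C)CCn1cnnc1-c1cc(Oc2ccc(NC(=O)N/N=C/c3ccccc3)cc2F)ccn1`, gives 2730 nM in this assay.

For the measured compounds named here, compound 2 stands at the higher of the two numbers measured so far, meaning weaker inhibition of cell growth. Going by the values given here, its only neighbour is compound 1, and the one measured step, a 3.5-fold higher number from compound 1 to compound 2 (0.54 log units; beyond the scatter), shows how much weaker the compound became when a phenyl took the place of the indolyl group on the carbon that carries the double bond to nitrogen.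

Compound 3, `CN(C)CCn1cnnc1-c1cc(Oc2ccc(NC(=O)N/N=C/c3ccc(F)cc3)cc2F)ccn1`, differs from compound 2 in one place: fluoro in place of hydrogen on an aromatic carbon. The fluoro sits para to a large group, so the phenyl becomes a 4-fluorophenyl.

Among the compounds with values here, no measured step changes a single substituent on that phenyl ring; the step from compound 1 to compound 2 swaps the whole ring system and does not show what one fluoro on it does. With nothing pointing either way, the expected step is none beyond the scatter. Compound 3 is therefore estimated at about 2500 nM, within a range from 1000 nM to 6500 nM. The expected change is a 1.1-fold lower number from compound 2 to compound 3 (0.04 log units; within the scatter), essentially flat.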

Compound 3, half-maximal inhibitory concentration: 1030 nM
Compound 3: the middle estimate sits 2.4-fold (0.39 log units) above what was measured, and the stated range covers the measured number.
By their numbers in this assay, from the lowest: compounds 1 and 3 (each within the scatter of the next); then compound 2.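

In this assay a single atom on the phenyl ring matters: fluoro in place of hydrogen on an aromatic carbon, para to a large group, gives a 2.7-fold lower number from compound 2 to compound 3 (0.42 log units; beyond the scatter) and this is something the earlier step, which swapped a whole ring system, could not show. The swap of 1H-indol-3-yl for 4-fluorophenyl gives a 1.3-fold higher number from compound 1 to compound 3 (0.12 log units; within the scatter) so the gap that opened when plain phenyl replaced the 1H-indol-3-yl group is no longer seen once this one fluoro is present, and the larger ring system shows no advantage over 4-fluorophenyl in these compounds. No measured evidence is available to explain why the fluoro changes the number, so the step stands as an observation only.

Going by these compounds, it remains open whether this gain is particular to fluoro or would also come with another group at the same place, such as chloro, methoxy, an amine or a carboxylic acid. The compounds shown also leave unanswered what a fluoro would do on the 1H-indol-3-yl group of compound 1, and whether the two changes would add together.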